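Taking the Hydroxy Group off Compound 2

The compounds below may be only part of what the source reports. "The series", "measured", "known", "first", "only" and "open" are said of these compounds alone.

Of the compounds shown here, three that share a core have been measured so far in a functional assay, read by spectrophotometry, with a stated time of 2 h (a lower number here means a stronger inhibitor, a higher number a weaker inhibitor), to date. Compound 1 `CCOC(=O)C1=C(C)NC(=O)NC1c1cccc([N+](=O)[O-])c1` gives 27.7 ug/mL and compound 3 `CCOC(=O)C1=C(C)NC(=O)NC1c1ccc([N+](=O)[O-])cc1` gives 33.3 ug/mL on this scale, two values within the scatter of each other. Compound 2 `COC(=O)C1=C(C)NC(=O)NC1c1ccc(O)cc1` stands apart at 3.14 ug/mL as the lowest number of the three, beyond the scatter from both others, which makes it the strongest inhibitor of this small set.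

Compound 4 `COC(=O)C1=C(C)NC(=O)NC1c1ccccc1` changes one thing in compound 2 (hydrogen in place of hydroxy on an aromatic carbon), with hydrogen in place of hydroxy on an aromatic carbon. For the measured compounds named here, no measured pair shows this change on its own, so its size is uncertain. Going by the values given here, compound 2 (at 3.14 ug/mL) is the only measured compound carrying a hydroxy, though three compounds are thin evidence. A move toward a weaker inhibitor, beyond the scatter, is expected in this assay here, and the estimated step is a 5.7-fold higher number from compound 2 to compound 4 (0.76 log units; beyond the scatter) in size. Compound 4 is estimated at 18 ug/mL (expected range 7 ug/mL to 45 ug/mL).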

Compound 4, half-maximal inhibitory concentration: 28.4 ug/mL
Compound 4: the middle estimate sits 1.6-fold (0.20 log units) below what was measured; measured number inside the range.
By their numbers in this assay, from the lowest: compound 2; then compounds 1, 4 and 3 (each within the scatter of the next).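

In this assay, hydrogen in place of hydroxy, on an aromatic carbon para to a large group, gives a 9.0-fold higher number from compound 2 to compound 4 (0.96 log units; beyond the scatter). The earlier compounds shown here differed from compound 2 in more than one place, so they could not tie its low number to any single group; this pair changes one place only and links the lower number to the hydroxy at this position. Nothing shown here measures why the hydroxy makes this difference.

On these data alone, it remains open whether another group in the same place, such as a methoxy group, an amine or a fluorine atom, would keep the lower number or lose it as hydrogen does. Also open, as far as these compounds go, is whether a hydroxy elsewhere on the same aromatic ring would give a similar step.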